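Removing One Methyl from Compound 3

This account rests on a few compounds, and the source may have more. Where it says the series, first, only, none or still open, it means among the compounds named here.

In a functional assay on PBMC cells (Homo sapiens) for inhibition, with a stated time of 24 h (a higher number here means a weaker inhibitor, a lower number a stronger inhibitor), compound 1 (`NCC1(c2cccc(-c3ccnc4[nH]ncc34)c2)CCC1`) gives 300 nM and compound 2 (`NCC1(c2cccc(-c3ccnc4[nH]ncc34)c2)CCOCC1`) gives 550 nM as its value, two numbers within the scatter of each other. Compound 3 (`Cc1cc(-c2ccnc3[nH]nc(C(F)(F)F)c23)cc(C2(CN)CCC2)c1`) reaches 60 nM and so holds the lowest number of the three, beyond the scatter from both others. Compound 4 (`NCC1(c2cccc(-c3ccnc4[nH]nc(C(F)(F)F)c34)c2)CCC1`) remains unmeasured. It has hydrogen in place of methyl on an aromatic carbon and otherwise matches compound 3. Going by the values given here, no measured pair isolates this change, so the expectation is loose: a modest rise in the number in this assay, meaning a somewhat weaker inhibitor, perhaps not beyond the scatter. The expected change is a 1.8-fold higher number from compound 3 to compound 4 (0.26 log units; within the scatter) in size. The estimate for compound 4 is 110 nM with an expected range from 40 nM to 280 nM in this measurement.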

Compound 4, half-maximal inhibitory concentration: 90 nM
Compound 4: the middle estimate sits 1.2-fold (0.09 log units) above what was measured; the range from low to high includes it.
By their numbers in this assay, from the lowest: compounds 3 and 4 (each within the scatter of the next); then compounds 1 and 2 (each within the scatter of the next).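

In this assay, going by these compounds alone, the first single-place comparison at this aromatic carbon shows that hydrogen in place of methyl gives a 1.5-fold higher number from compound 3 to compound 4 (0.18 log units; within the scatter), so the methyl makes no readable difference here. Within the data shown here, compound 4 also isolates the trifluoromethyl group, and adding it gives a 3.3-fold lower number from compound 1 to compound 4 (0.52 log units; beyond the scatter), the only one of these two steps beyond the scatter. Nothing available explains either step.

The compounds shown leave open whether ethyl or chlorine at this aromatic carbon would read differently. They also leave open whether trifluoromethyl would give a similar step on the core of compound 2.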